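The source may report more compounds than this note shows. Statements on the series, on what has been measured and on what is new or still open speak of the compounds shown alone.

Three compounds have been measured in an assay on isolated protein for inhibition of myosin-2 (Bos taurus), read by spectrophotometry, with a stated time of 24 min; on this read-out higher numbers stand for weaker inhibition and lower numbers for stronger inhibition:

- compound 1, `C/C(=N\CC(C)C)c1c(O)c2ccccc2oc1=O`, gives 34000 nM.
- compound 2, `CCCC/N=C(\C)c1c(O)c2ccccc2[nH]c1=O`, reaches only the assay limit, >= 100000 nM.
- compound 3, `CC/C(=N\Cc1ccccc1)c1c(O)c2ccccc2oc1=O`, likewise stops at the assay limit, >= 100000 nM.

Going by the values given here, compound 1 therefore stands as the only real number in this assay; the other two values sit at the limit of >= 100000 nM in this assay, at which 2 of the 3 values shown sit. Among the compounds with values here, no pair of measured compounds differs in a single place, so no measured step can be used as a guide. Compound 4, `CCCCC/N=C(\C)c1c(O)c2ccccc2oc1=O`, differs from compound 1 by butyl in place of isopropyl on a saturated chain carbon bound to a double-bonded nitrogen. With nothing to anchor the direction, the step from compound 1 to compound 4 is expected to stay within the usual scatter, no change at the digits printed from compound 1 to compound 4 (within the scatter). Compound 4 is thus estimated at 34000 nM, between 11000 nM and 100000 nM.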

Compound 4, half-maximal inhibitory concentration: 6700 nM
Beside the measured number, compound 4's estimate is 5.1-fold (0.71 log units) above it; measured number outside the range, below it.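

In this assay, butyl in place of isopropyl on a saturated chain carbon bound to a double-bonded nitrogen gives a 5.1-fold lower number from compound 1 to compound 4 (0.71 log units; beyond the scatter). Going by these compounds alone, this is the first readable step, and it shows that this chain alone can shift the read-out beyond the scatter, with the core unchanged. Only compound 1 and compound 4 carry real numbers, so the comparison rests on this single pair: the limit of >= 100000 nM in this assay, at which 2 of the 4 values shown sit.

As far as these compounds go, whether a longer chain such as hexyl would lower the number further remains open. So does the effect of an amine or a carboxylic acid at the end of the chain.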